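Sulfonate ester series: methoxy to fluoro on the phenoxy ring

This account rests on a few compounds, and the source may have more. Where it says the series, first, only, none or still open, it means among the compounds named here.

Measured in a functional assay on HT-29 cells (Homo sapiens) for antiproliferative activity, read by sulforhodamine B assay, with a stated time of 48 h; on this read-out higher numbers stand for weaker inhibition and lower numbers for stronger inhibition:
- compound 1 `CCCCN1CCN(c2ccc(S(=O)(=O)Oc3ccccc3OC)cc2)C1=O`: > 100000 nM, a limit of the assay and not a number.
- compound 2 `CCCCN1CCN(c2ccc(S(=O)(=O)Oc3cccc(OC)c3)cc2)C1=O`: 13000 nM.

Among the compounds with values here, compound 2 holds the only number in this assay; the other value belongs to compound 1 and is a limit (the limit of > 100000 nM in this assay, at which 1 of the 2 values shown sits). Within the data shown here, the single measured step, an at least 7.6-fold lower number from compound 1 to compound 2 (0.88 log units; beyond the scatter), comes with 3-methoxyphenyl in place of 2-methoxyphenyl on an oxygen, so it speaks to where the methoxy sits, not to what group sits there.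

Compound 3 `CCCCN1CCN(c2ccc(S(=O)(=O)Oc3cccc(F)c3)cc2)C1=O` differs from compound 2 by fluoro in place of methoxy on an aromatic carbon. Among the measured compounds shown here, no measured step exchanges the methoxy for another group, so the step from compound 1 to compound 2 does not bear directly on this change, and the series offers no guide to its direction. In this assay the expectation for compound 3 is therefore a step of a 1.5-fold higher number from compound 2 to compound 3 (0.19 log units; within the scatter), that is, none beyond the scatter, with a wide margin either way. Compound 3 is estimated at 20000 nM, between 5000 nM and 80000 nM.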

Compound 3, half-maximal inhibitory concentration: 76000 nM
Compound 3: the middle estimate sits 3.8-fold (0.58 log units) below what was measured; measured number inside the range.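

In this assay, the exchange of methoxy for fluoro gives a 5.8-fold higher number from compound 2 to compound 3 (0.77 log units; beyond the scatter), so the identity of the group on this ring moves the number, whereas the earlier step spoke only to where the methoxy sits. Among the three compounds, compound 2 keeps the lowest number, and its steps to both others are printed as beyond the scatter, so fluoro does not serve as a like-for-like replacement for methoxy at this place in this assay. The remaining comparison reads an at least 1.3-fold lower number from compound 1 to compound 3 (0.11 log units; that floor lies within the scatter), and with that floor inside the scatter it sets no order between these two compounds.

Within the data shown here, the value of compound 1 is a limit of the assay and not a number, so how far it lies from compound 3 stays open: the limit of > 100000 nM in this assay, at which 1 of the 3 values shown sits. Also open is whether an amine, a hydroxyl or a longer alkoxy chain in place of the methoxy on the 3-methoxyphenyl ring would bring the number below that of compound 2, since methoxy and fluoro are the only two groups compared at this place.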